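Working notes: one stereocentre inverted

A few compounds are considered here, and "the series" means these few. Any claim that something is new, unique, unknown or untested is made for them only; others in the source may bear on it.

Measured so far in a functional assay on HCT-15 cells (Homo sapiens) for antiproliferative activity, with a stated time of 48 h; on this read-out higher numbers stand for weaker inhibition and lower numbers for stronger inhibition:
- compound 1 `Cc1cc(=O)c2c(O)cc(OC[C@H]3CO3)cc2o1` gives 27200 nM as its value
- compound 2 `Cc1cc(=O)c2c(OC[C@@H]3CO3)cc(OC[C@@H]3CO3)cc2o1` gives 39500 nM as its value

Within the data shown here, compound 2 lies within the scatter of compound 1, the only other compound measured, so these numbers do not separate the two. The next compound is compound 3 `Cc1cc(=O)c2c(OC[C@@H]3CO3)cc(OC[C@H]3CO3)cc2o1`, and the structural change is the two compounds have the same atoms and bonds and differ only in configuration as drawn: 1 of 2 stereo elements differ; a stereocentre at a saturated ring carbon is drawn S in compound 2 and R in compound 3. The stereocentre concerned sits at a saturated ring carbon, drawn S in compound 2 and R in compound 3. Among the measured compounds shown here, no measured pair differs only in configuration, so the data offer no direct guide to this change. In this assay no step beyond the scatter is expected, in either direction. The expected size is a 1.1-fold lower number from compound 2 to compound 3 (0.04 log units; within the scatter) in this estimate. The expectation is anchored on compound 2 at 39500 nM as its starting point. For compound 3 the estimated value is 36000 nM, with an expected range from 18000 nM to 70000 nM overall.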

Compound 3, half-maximal inhibitory concentration: 12100 nM
Estimate against measurement, compound 3: 3.0-fold (0.47 log units) above; the whole stated range lies above it.
By their numbers in this assay, from the lowest: compound 3; then compounds 1 and 2 (each within the scatter of the next).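

In this assay, among these compounds, the configuration at a single saturated ring carbon now separates two compounds, which no earlier pair could show: inverting this one stereocentre gives a 3.3-fold lower number from compound 2 to compound 3 (0.51 log units; beyond the scatter). The basis for assigning that step to configuration alone is: the fact that compounds 2 and 3 differ only in the configuration as drawn. The change of (oxiran-2-yl)methyl in place of hydrogen on an oxygen on an aromatic ring also gives a step beyond the scatter, a 2.2-fold lower number from compound 1 to compound 3 (0.35 log units; beyond the scatter), so with this configuration as drawn, the added group goes with a lower number.

The compounds shown leave open whether inverting the other stereocentre gives a step of similar size and direction. They also leave open whether the oxirane ring itself matters, which a diol or an amine in its place would test.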